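A few compounds are considered here, and "the series" means these few. Any claim that something is new, unique, unknown or untested is made for them only; others in the source may bear on it.

Measured in an assay on isolated protein for inhibition of acid ceramidase (Homo sapiens), read by LC-MS, with a stated time of 1 h; a higher number here means a weaker inhibitor, a lower number a stronger inhibitor:
compound 1 `COc1ccc(-c2cn(C(=O)NCCCCc3ccccc3)c(=O)o2)cc1` — 400 nM
compound 2 `COc1cccc(-c2cn(C(=O)NCCCCc3ccccc3)c(=O)o2)c1` — 341 nM
compound 3 `COc1cc(-c2cn(C(=O)NCCCCc3ccccc3)c(=O)o2)ccc1F` — 80 nM

Compound 3 gives the lowest number of the three. The step of a 1.2-fold lower number from compound 1 to compound 2 (0.07 log units; within the scatter) lies within the scatter, so compounds 1 and 2 cannot be ordered against each other. By contrast, a 5.0-fold lower number from compound 1 to compound 3 (0.70 log units; beyond the scatter) and a 4.3-fold lower number from compound 2 to compound 3 (0.63 log units; beyond the scatter) are both modest steps beyond the scatter, and compound 3 stands clear of both.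

Compound 4 `O=C(NCCCCc1ccccc1)n1cc(-c2ccccn2)oc1=O` carries the change (pyridin-2-yl in place of 4-fluoro-3-methoxyphenyl on an aromatic carbon). Among the measured compounds shown here, none of the measured steps covers a change of this kind: all three vary only the methoxy and fluoro substitution on a phenyl ring, whereas here that ring is replaced outright. What the steps do show is that compound 3 is set apart from compounds 1 and 2 only by substituents that leave in compound 4. The gain seen in a 4.3-fold lower number from compound 2 to compound 3 (0.63 log units; beyond the scatter) is therefore expected to be given back, and the number for compound 4 is expected to move back at least into the region of compounds 1 and 2. Whether the pyridin-2-yl brings a further shift in either direction cannot be read from these data, so the range is kept wide. The estimate for compound 4 in this assay is 500 nM, range 150 nM to 2000 nM, an expected step of a 6.3-fold higher number from compound 3 to compound 4 (0.80 log units; beyond the scatter).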

Compound 4, half-maximal inhibitory concentration: 25 nM
Beside the measured number, compound 4's estimate is 20-fold (1.30 log units) above it, outside the stated range (below it).
By their numbers in this assay, from the lowest: compound 4; then compound 3; then compounds 2 and 1 (each within the scatter of the next).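

In this assay, the position next to the ring oxygen does not depend on the 4-fluoro-3-methoxyphenyl group: with pyridin-2-yl in its place the result is a 3.2-fold lower number from compound 3 to compound 4 (0.51 log units; beyond the scatter), so the number falls further instead of returning towards the other phenyl compounds. The gaps to those compounds are wider, at a 14-fold lower number from compound 2 to compound 4 (1.13 log units; beyond the scatter) and a 16-fold lower number from compound 1 to compound 4 (1.20 log units; beyond the scatter), so neither methoxy nor fluoro is needed for a low number here, and a six-membered aromatic ring with 1 hetero atom and fewer heavy atoms gives a lower number than all three substituted phenyl groups shown. Nothing at hand explains this change in the number.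

Going by these compounds, the change alters the ring and removes both substituents in a single step, so it remains open whether the ring nitrogen or the loss of methoxy and fluoro carries the gain; unsubstituted phenyl, pyridin-3-yl and pyridin-4-yl at the same carbon would separate these. Also open, on these data alone, is whether fluoro or methoxy on the pyridin-2-yl ring would lower the number further or raise it.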